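This account rests on a few compounds, and the source may have more. Where it says the series, first, only, none or still open, it means among the compounds named here.

Working notes on the series, with lipophilicity read in a physicochemical assay for lipophilicity, using the shake flask method, in phosphate buffer, measured as octanol-water partition, at pH 7.4; a lower number here means a more polar compound, a higher number a more lipophilic compound. Compound 1 (`C[C@@H]1CN(C(=O)OC(C)(C)C)CCN1c1ncc(OCC2CCN(S(C)(=O)=O)CC2)cn1`) gives 3.5. Compound 2 (`C[C@@H]1CN(C(=O)OC(C)(C)C)CCN1c1ncc(OCc2ccc(C#N)cc2)cn1`) gives > 3.6, which is a limit and not a number. Its position is therefore known only through (the limit of > 3.6 in this assay, at which 1 of the 2 values shown sits).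

The next exchange leads to compound 3 (`C[C@@H]1CN(C(=O)OC(C)(C)C)CCN1c1ncc(OCc2ccc(-n3cnnn3)cc2)cn1`): 1H-tetrazol-1-yl in place of cyano on an aromatic carbon, so 4-cyanophenyl becomes 4-(1H-tetrazol-1-yl)phenyl. The count is 1H-tetrazol-1-yl in place of cyano on an aromatic carbon.

Within the data shown here, the only measured step is a number at least 0.10 log units higher from compound 1 to compound 2 (that floor lies within the scatter). It exchanges 1-(methylsulfonyl)piperidin-4-yl for 4-cyanophenyl, so it is a different change and gives no direct size for this one. The starting point, compound 2 at > 3.6, is also a limit. With so little to go on, only a modest fall in this assay is expected, resting on the entering group's one five-membered aromatic ring with 4 hetero atoms, and it may not clear the scatter. The expected change is a number at least 0.20 log units lower from compound 2 to compound 3 (that floor lies within the scatter). For compound 3 the estimated value is 3.4. The expected range for compound 3 runs from 3 to 3.8.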

Compound 3, distribution coefficient: > 4.3
Compound 3: a limit, no number; the forecaster's own chance of this, stated with the estimate: 20%; at least 0.90 log units between middle value and limit.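

In this assay compound 3 gives > 4.3, which is a limit and not a number, and its position is known only through that limit: the limit of > 4.3 in this assay, at which 1 of the 3 values shown sits. Even so, 4-(1H-tetrazol-1-yl)phenyl in place of 1-(methylsulfonyl)piperidin-4-yl gives a number at least 0.80 log units higher from compound 1 to compound 3 (beyond the scatter), the first step in the series that reads as beyond the scatter, since the floor of the earlier step with 4-cyanophenyl lay within it. The step from cyano to 1H-tetrazol-1-yl on the aromatic carbon cannot be read, as both of its ends are limits, so the one five-membered aromatic ring with 4 hetero atoms has no measured size of effect here, only a floor against the 1-(methylsulfonyl)piperidin-4-yl end.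

Going by these compounds, how far compound 3 lies beyond its limit, and whether 1H-tetrazol-1-yl differs from cyano at all, stays open. Also open, on these data alone, is whether a carboxylic acid or an amine on the same aromatic carbon would give a number in this assay and so turn this position into a readable comparison.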